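Swapping the aryl end of a diether linker

The source may hold more compounds than are shown below. What is called first, only, known or untested is meant among the compounds shown, and "the series" means these compounds.

Measured compounds:
compound 1 `CCC(=O)c1ccc(OCCCCOc2ccc(F)c(C(=O)O)c2)c(C)c1O`, an assay on HEK293 cells for positive allosteric modulation of metabotropic glutamate receptor 3 (Rattus norvegicus), read by thallium flux, with a stated time of 2.5 min; on this read-out higher numbers stand for an effect only at larger amounts of compound and lower numbers for an effect already at smaller amounts: "not determined" (no result reported)
compound 2 `Cc1cc(OCCCCOc2ccc(C(=O)CC3CCCC3)c(O)c2C)ccc1C(=O)O`, this assay: > 10000 nM

Compound 2 stands as the only entry with any figure, and that figure is a limit of the assay rather than a number; the other entry, compound 1, carries no result at all. Among the compounds with values here, the one piece of evidence is the limit of > 10000 nM in this assay, at which 1 of the 2 values shown sits.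

Compound 3 `Cc1c(OCCCCOc2ccc(F)c(C(=O)O)c2)ccc(C(=O)CC2CCCC2)c1O` is built from compound 2 by the change (3-carboxy-4-fluorophenyl in place of 4-carboxy-3-methylphenyl on an oxygen on a saturated carbon), that is, 3-carboxy-4-fluorophenyl in place of 4-carboxy-3-methylphenyl on an oxygen on a saturated carbon. Within the data shown here, no measured pair shows what such a swap does, so no direction can be read from the data, and the step from compound 2 to compound 3 is expected to stay within scatter, as an at least 1.1-fold lower number from compound 2 to compound 3 (0.04 log units; that floor lies within the scatter).

Compound 3 is therefore estimated at 9000 nM, within 2000 nM to 30000 nM, with a fair chance that only a limit is reported again.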

Compound 3, half-maximal effective concentration: 2490 nM
Compound 3: the middle estimate sits 3.6-fold (0.56 log units) above what was measured; low and high end bracket the measured number.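

Putting 3-carboxy-4-fluorophenyl in place of 4-carboxy-3-methylphenyl on an oxygen on a saturated carbon gives, in this assay, an at least 4.0-fold lower number from compound 2 to compound 3 (0.60 log units; beyond the scatter). This end of the molecule therefore matters: both groups have the same heavy-atom count and both carry a carboxy group, yet the change lies beyond the usual scatter and makes compound 3 the only one of the three with a single number. From the compounds shown here alone, the true size of the step stays unknown, since one of its ends is a limit: the limit of > 10000 nM in this assay, at which 1 of the 3 values shown sits.

A single swap cannot separate the part played by the fluorine, the lost methyl or the different place of the carboxy group. Also open, going by these compounds, are how a chlorine or a tetrazole would fare on this ring and, with no result for compound 1, what the other end of the molecule contributes.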